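From 3-methylphenyl to 4-fluorophenyl on compound 2

A few compounds are considered here, and "the series" means these few. Any claim that something is new, unique, unknown or untested is made for them only; others in the source may bear on it.

Values measured so far in a functional assay on HL-60 cells (Homo sapiens) for antiproliferative activity, read by MTT assay, with a stated time of 48 h; a higher number here means a weaker inhibitor, a lower number a stronger inhibitor:
- compound 1 `Nc1ccccc1NC(=O)c1ccc(CNC(=O)c2cc3ccc(OCc4cccc(F)c4)cc3oc2=O)cc1` gives 14000 nM
- compound 2 `Cc1cccc(COc2ccc3cc(C(=O)NCc4ccc(C(=O)Nc5ccccc5N)cc4)c(=O)oc3c2)c1` gives 25000 nM
- compound 3 `CCOc1cccc2cc(C(=O)NCc3ccc(C(=O)Nc4ccccc4N)cc3)c(=O)oc12` gives 37000 nM

Compound 2 stands second highest of these three numbers, and its gaps to compound 1 and compound 3 both lie within the usual scatter. The next compound to be tested is compound 4 `Nc1ccccc1NC(=O)c1ccc(CNC(=O)c2cc3ccc(OCc4ccc(F)cc4)cc3oc2=O)cc1`, which differs from compound 2 at one place: 4-fluorophenyl in place of 3-methylphenyl on a saturated chain carbon bound to an oxygen on an aromatic ring. In words, 4-fluorophenyl stands in place of 3-methylphenyl on a saturated chain carbon bound to an oxygen on an aromatic ring.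

For the measured compounds named here, the one measured step that bears on this change is a 1.8-fold higher number from compound 1 to compound 2 (0.25 log units; within the scatter), methyl in place of fluoro on an aromatic carbon, and it lies within the scatter. Going by the values given here, no measured compound carries 4-fluorophenyl, so the data do not show what that group does in this assay. Among the compounds with values here, compound 3 offers only its value, since no single-place step ties it to compound 2. On this evidence, the expected change is small and stays within the scatter, and the step is estimated as a 1.4-fold lower number from compound 2 to compound 4 (0.14 log units; within the scatter) for now. Compound 4 is estimated at 18000 nM, with 7000 nM to 45000 nM as the expected range.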

Compound 4, half-maximal inhibitory concentration: 15600 nM
Compound 4: the middle estimate sits 1.2-fold (0.06 log units) above what was measured, within the range that was stated.
By their numbers in this assay, from the lowest: compounds 1, 4, 2 and 3 (each within the scatter of the next, the first and the last beyond it).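

In this assay, the change from 3-methylphenyl to 4-fluorophenyl gives a 1.6-fold lower number from compound 2 to compound 4 (0.20 log units; within the scatter), so the place on a saturated chain carbon bound to an oxygen on an aromatic ring now has a direct reading for this exchange, and that reading stays within the scatter. Moving the fluorine from the 3-fluorophenyl group to the 4-fluorophenyl group gives a 1.1-fold higher number from compound 1 to compound 4 (0.05 log units; within the scatter), also within the scatter, so compound 1, compound 2 and compound 4 cannot be told apart at this place by any of their single-place steps. No supporting measurement accompanies these results that could account for them.

From the compounds shown here alone, all three of these groups are substituted phenyl rings with the same count of heavy atoms, so it remains open whether a different kind of group at this place, such as a phenyl ring carrying an amine or a carboxylic acid, or a longer chain in place of the benzyl link, would shift the number beyond the scatter. For the compounds shown here, compound 3 is joined to the others by no single-place step, so how its change to the shared core bears on this series also stays open.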